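The compounds below may be only part of what the source reports. "The series", "measured", "known", "first", "only" and "open" are said of these compounds alone.

The starting point here is compound 2, `COC(=O)[C@@H]1CN(C)CC[C@@H]1c1ccc(-c2nccs2)cc1`. In an assay for displacement of a labelled ligand from sodium-dependent dopamine transporter (Rattus norvegicus) (a higher number here means a weaker inhibitor, a lower number a stronger inhibitor), compound 2 gives only a limit, > 10000 nM, rather than a measured number. Among the compounds with values here, its one measured relative is compound 1, `COC(=O)[C@@H]1CN(C)CC[C@@H]1c1ccc(-c2cccs2)cc1`, in which a thiophen-2-yl stands where compound 2 carries the 1,3-thiazol-2-yl. In this assay compound 1 also gives only a limit, >= 5000 nM. The step that the two limits leave unreadable from compound 1 to compound 2 therefore cannot be sized, since both values stop at a limit: the limit of > 10000 nM in this assay, at which 1 of the 2 values shown sits, and (the limit of >= 5000 nM in this assay, at which 1 of the 2 values shown sits). Compound 3, `COC(=O)[C@@H]1CN(C)CC[C@@H]1c1ccc(/C=C\I)cc1`, departs from compound 2 by a different kind of change, 2-iodoethenyl in place of 1,3-thiazol-2-yl on an aromatic carbon: a small open chain carrying iodine replaces the aromatic ring. Within the data shown here, no measured step covers an exchange of this kind, so the expectation rests only on the weak limits of compounds 1 and 2. Compound 3 is estimated at 500 nM in this assay, with a range of 50 nM to 5000 nM, meaning an expected step of an at least 20-fold lower number from compound 2 to compound 3 (1.30 log units; beyond the scatter).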

Compound 3, inhibition constant: 123 nM
Compound 3: middle estimate off by 4.1-fold (0.61 log units), on the high side, within the range that was stated.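

Until now, the two five-membered aromatic rings at this position, on an aromatic carbon para to a large group, had given only limits, so nothing showed that a group here could go with measurable binding. With 2-iodoethenyl in this assay, the change gives an at least 81-fold lower number from compound 2 to compound 3 (1.91 log units; beyond the scatter), and the comparison with the thiophen-2-yl compound gives an at least 40-fold lower number from compound 1 to compound 3 (1.60 log units; beyond the scatter). Both steps start from a limit, so each gives only the smallest size the step could have.

The compounds shown do not separate the part played by the iodine from that of the double bond or of the missing ring. A plain ethenyl, a 2-chloroethenyl or a phenyl at this position would help to tell these apart.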